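A few compounds are considered here, and "the series" means these few. Any claim that something is new, unique, unknown or untested is made for them only; others in the source may bear on it.

Working notes on the dichloroacetanilide series. The parent, compound 1 `O=C(Nc1ccccc1)C(Cl)Cl`, gives 130000 nM in a functional assay on A549 cells (Homo sapiens) for antiproliferative activity, read by MTT assay, with a stated time of 72 h; on this read-out higher numbers stand for weaker inhibition and lower numbers for stronger inhibition. Going by the values given here, compound 2 `O=C(Nc1cccc(I)c1)C(Cl)Cl`, iodo in place of hydrogen on an aromatic carbon, gives 4760 nM; the step of a 27-fold lower number from compound 1 to compound 2 (1.44 log units; beyond the scatter) makes compound 2 the lowest of the two numbers so far. Compound 3 `O=C(Nc1cccc(OC(F)(F)F)c1)C(Cl)Cl` differs from compound 2 by trifluoromethoxy in place of iodo on an aromatic carbon. Among the compounds with values here, only the step from compound 1 to compound 2 bears on this change, and it concerns a different group, so the size of the new step is uncertain. Retaining a substituent on that aromatic carbon is expected to hold much of the gain seen in a 27-fold lower number from compound 1 to compound 2 (1.44 log units; beyond the scatter), with a modest drift upward, a 1.7-fold higher number from compound 2 to compound 3 (0.23 log units; within the scatter). Compound 3 is therefore expected near 8000 nM, between 2500 nM and 25000 nM.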

Compound 3, half-maximal inhibitory concentration: 15100 nM
Beside the measured number, compound 3's estimate is 1.9-fold (0.28 log units) below it, within the range that was stated.
By their numbers in this assay, from the lowest: compound 2; then compound 3; then compound 1.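

The gain at this aromatic carbon is not confined to iodo: trifluoromethoxy also gives an 8.6-fold lower number from compound 1 to compound 3 (0.93 log units; beyond the scatter) in this assay on the shared core. The choice of group still matters here, with a 3.2-fold higher number from compound 2 to compound 3 (0.50 log units; beyond the scatter) leaving iodo ahead of trifluoromethoxy on this carbon. No supporting data are available to explain the difference between the two groups.

As far as these compounds go, whether an amine, a carboxylic acid or a methyl group on the same carbon would hold the gain remains open. Also open, from the compounds shown here alone, is how iodo and trifluoromethoxy would compare on another carbon of the ring.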